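The compounds below may be only part of what the source reports. "The series", "measured", "known", "first", "only" and "open" are said of these compounds alone.

In a functional assay on NALM-6 cells (Homo sapiens) for cytotoxicity, with a stated time of 72 h (a higher number here means that more compound is needed for the effect, a lower number that less compound is needed), compound 1 `C=C[C@@](C)(/C=C/c1ccc(-c2ccc(F)cc2)cc1)CCC=C(C)C` gives > 43400 nM, which is a limit and not a number. Compound 2 `C=C[C@@](C)(/C=C/c1ccc(-c2ccc(Cl)c(Cl)c2)cc1)CCC=C(C)C` gives > 43400 nM, also a limit, so its standing is known only as the limit of > 43400 nM in this assay, at which 2 of the 2 values shown sit. Compound 3 `C=C[C@@](C)(/C=C/c1ccc(-c2cccc(Br)c2)cc1)CCC=C(C)C` differs from compound 2 by 3-bromophenyl in place of 3,4-dichlorophenyl on an aromatic carbon, with 3-bromophenyl in place of 3,4-dichlorophenyl on an aromatic carbon, para to a large group. Within the data shown here, the one measured step that bears on this, a step that the two limits leave unreadable from compound 1 to compound 2, is a change of group at the same place and gives no size. No defined direction or size of change is therefore expected in this assay, and the expected step is a number no higher from compound 2 to compound 3 (the limit leaves the size open). For compound 3 the estimated value is 43400 nM, with an expected range of 20000 nM to 80000 nM.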

Compound 3, half-maximal effective concentration: > 43400 nM
Compound 3: only a limit was reported; the forecaster's own chance of this, stated with the estimate: 80%; the middle value sits exactly at the limit.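

Among these compounds, compound 3 gives > 43400 nM in this assay, again a limit, so no step among compound 1, compound 2 and compound 3 can be read. The compounds shown leave open whether exchanging these halogenated phenyl groups changes the value at all.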